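A few compounds are considered here, and "the series" means these few. Any claim that something is new, unique, unknown or untested is made for them only; others in the source may bear on it.

Series notes. Compound 1 `CC#CCn1c(N2CCC[C@@H](N)C2)cc(=O)n(Cc2ccc(Cl)c(C(=O)O)c2)c1=O` is the reference point. In an assay on isolated protein for inhibition of Dipeptidyl peptidase 9 (Homo sapiens), read by fluorescence, with stated times of 15 min and 20 min (a lower number here means a stronger inhibitor, a higher number a weaker inhibitor), compound 1 gives only a limit, > 100 nM. Among the compounds with values here, compound 2 `CC#CCn1c(N2CCC[C@@H](N)C2)cc(=O)n(Cc2cc(C(=O)O)ccc2F)c1=O` is the single measured neighbour. In this assay compound 2 also gives only a limit, > 100 nM. The step that the two limits leave unreadable from compound 1 to compound 2 cannot be read, and the whole of the evidence is the limit of > 100 nM in this assay, at which 2 of the 2 values shown sit. Compound 3 `CC#CCn1c(N2CCC[C@@H](N)C2)cc(=O)n(Cc2ccc(Cl)c(C(=O)OC)c2)c1=O` differs from compound 1 by methyl in place of hydrogen on an oxygen next to a carbonyl group. Within the data shown here, no measured step carries this change, so for compound 3 the expected step that the limit leaves unreadable from compound 1 to compound 3 has no readable direction beyond the scatter. Compound 3 is estimated at 300 nM, expected between 60 nM and 3000 nM.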

Compound 3, half-maximal inhibitory concentration: > 100 nM
Compound 3 ended at the assay's limit (the forecaster's own chance of this, stated with the estimate: 60%); the middle value does not contradict the limit.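

Within the data shown here, compound 1 and compound 3 both stand only as limits, so no step between them can be read. The compounds shown leave open where in this assay any of them truly lies, and whether methoxycarbonyl in place of carboxy changes anything.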